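This account rests on a few compounds, and the source may have more. Where it says the series, first, only, none or still open, it means among the compounds named here.

Working notes on the series. Compound 1 `CC(C)(C)c1csc(N)c1C(=O)c1ccc(Cl)cc1`, compound 2 `Cc1c(-c2ccccc2)sc(N)c1C(=O)c1ccc(Cl)cc1` and compound 3 `CC(C)(C)Cc1c(-c2cccnc2)sc(N)c1C(=O)c1ccc(Cl)cc1` share one core and were run in an assay on CHO cells for displacement of a labelled ligand from adenosine receptor A1 (Homo sapiens), read by scintillation counting, tested at 10 uM; on this read-out higher numbers stand for more inhibition at the one concentration tested (going by the name of the read-out) and lower numbers for less inhibition. In this assay compound 1 gives 1%, compound 2 gives 1% and compound 3 gives 1%. Compound 3 thus stands level with compounds 1 and 2 at the digits recorded; nothing separates the three beyond the scatter. Next comes compound 4, `CC(C)(C)Cc1c(-c2cc(F)ccc2F)sc(N)c1C(=O)c1ccc(Cl)cc1`, not yet measured. Relative to compound 3 the change is 2,5-difluorophenyl in place of pyridin-3-yl on an aromatic carbon. Among the compounds with values here, no step between measured compounds is available, and the three flat values give no footing for any direction. The step expected in this assay is a number 1 percentage points higher from compound 3 to compound 4 (within the scatter), none beyond the scatter. Compound 4 is estimated at 2%, with a range from -8% to 12%.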

Compound 4, a percentage reported as inhibition, at one concentration (the size of the read-out at that concentration, not a potency): 3%
The estimate for compound 4 lay 1 percentage points below the measured number; measured number inside the range.
By their numbers in this assay, from the lowest: compounds 1, 2, 3 and 4 (each within the scatter of the next).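

In this assay the step is a number 2 percentage points higher from compound 3 to compound 4 (within the scatter) with 2,5-difluorophenyl in place of pyridin-3-yl on the aromatic carbon next to the ring sulfur. Within the data shown here, this is the first comparison that differs in one place, and it shows that this exchange of aromatic rings does not move the read-out beyond the scatter. No evidence on a cause is available for this result. Still open, on these data alone, is whether an amine or a carboxylic acid at this position, or a longer chain in place of the neopentyl group, would lift the read-out beyond the scatter.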